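The source may report more compounds than this note shows. Statements on the series, on what has been measured and on what is new or still open speak of the compounds shown alone.

Measured compounds:

Compound 1 `O=C(NCc1ccc(F)cc1)c1ncc([N+](=O)[O-])[nH]1`; compound 2 `O=C(NCc1ccc(OC(F)(F)F)cc1)c1ncc([N+](=O)[O-])[nH]1`; compound 3 `NC(=O)c1nc([N+](=O)[O-])cn1Cc1ccc(F)cc1`.

In a toxicity assay on HEK293 cells (Homo sapiens) for inhibition, read by resazurin assay, with a stated time of 24 h (a lower number here means that less compound is tolerated, a higher number that more compound is tolerated), compound 1 gives > 100000 nM, which is a limit of the assay and not a number. In this assay compound 2 gives > 100000 nM, again a limit. In this assay compound 3 gives > 100000 nM, also a limit. The change from compound 1 to compound 2 is trifluoromethoxy in place of fluoro on an aromatic carbon; its step is a step that the two limits leave unreadable from compound 1 to compound 2, and that is all the two limits show, since (the limit of > 100000 nM in this assay, at which 3 of the 3 values shown sit). The difference between the core of compound 1 and the core of compound 3 is not broken down here. Compound 4 `NC(=O)c1nc([N+](=O)[O-])cn1Cc1ccc(OC(F)(F)F)cc1` is not yet measured; it carries the same change, (trifluoromethoxy in place of fluoro on an aromatic carbon). For compound 4 in this assay the expected step is a step that the limit leaves unreadable from compound 3 to compound 4, resting on compound 3 with > 100000 nM and on compounds 1 and 2 both sitting at the limit. Compound 4 is estimated at 150000 nM, between 70000 nM and 500000 nM.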

Compound 4, half-maximal cytotoxic concentration: > 100000 nM
Compound 4 ended at the assay's limit (the forecaster's own chance of this, stated with the estimate: 85%); the middle value is on the limit's open side.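

No new step can be read from compound 3 to compound 4 in this assay, since both compounds sit at a limit: the limit of > 100000 nM in this assay, at which 4 of the 4 values shown sit.

The compounds shown leave open whether trifluoromethoxy in place of fluoro changes tolerance in this assay on either core.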